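A few compounds are considered here, and "the series" means these few. Any claim that something is new, unique, unknown or untested is made for them only; others in the source may bear on it.

Measured compounds:

Compound 1, `CC(=O)c1cccc(-c2ccc(C(=O)N(Cc3cccc(OCCCCCC(=O)O)c3)C(C)C)cc2)c1`: in an ADME assay on HEK293 cells (Homo sapiens) for cytotoxicity, read by CellTiter-Glo and resazurin assay, with a stated time of 72 h (a lower number here means that less compound is needed, a higher number that more compound is needed for the effect), compound 1 gives > 26000 nM, which is a limit of the assay and not a number.
Compound 2, `CC(C)N(Cc1cccc(OCCCCCC(=O)O)c1)C(=O)c1ccc(-c2ccoc2)cc1`: in this assay compound 2 gives > 26000 nM, again a limit.
Compound 3, `CC(C)N(Cc1cccc(OCCCCCC(=O)O)c1)C(=O)c1ccc(-c2ccsc2)cc1`: in this assay compound 3 gives > 26000 nM, also a limit.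

Compound 2 therefore stands nowhere in particular among these numbers: its value in this assay is only a limit, and the two other values shown are limits as well. The unmeasured compound 4, `CC(C)N(Cc1cccc(OCCCCCC(=O)O)c1)C(=O)c1ccc(-c2cccc([N+](=O)[O-])c2)cc1`, differs from compound 2 by 3-nitrophenyl in place of furan-3-yl on an aromatic carbon.

Among the measured compounds shown here, three measured steps touch the same position. The step that the two limits leave unreadable from compound 1 to compound 2, the step that the two limits leave unreadable from compound 1 to compound 3 and the step that the two limits leave unreadable from compound 2 to compound 3 all run between two limits, so neither their size nor their direction can be read. For the measured compounds named here, the only evidence is the limit of > 26000 nM in this assay, at which 3 of the 3 values shown sit, where every value shown sits. On that basis nothing beyond the scatter can be foreseen in this assay in either direction for compound 4, and the most likely outcome is that compound 4 also returns a limit.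

Compound 4 is estimated at 26000 nM, with a range from 9000 nM to 100000 nM. The step expected on that estimate is a number no higher from compound 2 to compound 4 (the limit leaves the size open).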

Compound 4, half-maximal effective concentration: > 26000 nM
Compound 4: no number, only a limit (the forecaster's own chance of this, stated with the estimate: 85%); the middle value lies on the limit itself.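

In this assay compound 4 gives > 26000 nM, which is a limit of the assay and not a number, so its steps to compound 1, compound 2 and compound 3 cannot be read in size or direction. The compounds shown leave open whether any change at this position alters the result in this assay: the limit of > 26000 nM in this assay, at which 4 of the 4 values shown sit.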